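A few compounds are considered here, and "the series" means these few. Any claim that something is new, unique, unknown or untested is made for them only; others in the source may bear on it.

Compound 1, `COc1cc(-c2cc(/C=C/C(=O)c3ccccc3)[nH]n2)cc(OC)c1OC`: 2100 nM
Compound 2, `COc1cc(-c2cc(/C=C/C(=O)c3ccc(F)c(F)c3)[nH]n2)cc(OC)c1OC`: 2500 nM

In a functional assay on MCF7 cells (Homo sapiens) for inhibition, read by MTT assay, with a stated time of 48 h (on this read-out lower numbers stand for stronger inhibition and higher numbers for weaker inhibition), compound 2 gives 2500 nM, and the step of a 1.2-fold higher number from compound 1 to compound 2 (0.08 log units; within the scatter) places it within the scatter of compound 1, so the two cannot be told apart. Compound 3, `COc1cc(-c2cc(/C=C/C(=O)c3ccc(Cl)cc3)[nH]n2)cc(OC)c1OC`, differs from compound 2 in one place: 4-chlorophenyl in place of 3,4-difluorophenyl on a carbonyl carbon. Among the compounds with values here, the only step that bears on this position, a 1.2-fold higher number from compound 1 to compound 2 (0.08 log units; within the scatter), came from putting two fluorine atoms on that ring and stayed within the scatter. A second change of halogen on the same ring is therefore expected to move the number by a 1.1-fold lower number from compound 2 to compound 3 (0.04 log units; within the scatter), not beyond the scatter. Compound 3 is estimated at 2300 nM, between 1000 nM and 5500 nM.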

Compound 3, half-maximal inhibitory concentration: 11600 nM
The estimate for compound 3 lay 5.0-fold (0.70 log units) below the measured number; the measured number lies above the stated range.
By their numbers in this assay, from the lowest: compounds 1 and 2 (each within the scatter of the next); then compound 3.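

Changes on the ring attached to the carbonyl carbon can move the number: in this assay the 4-chlorophenyl group gives a 4.6-fold higher number from compound 2 to compound 3 (0.67 log units; beyond the scatter) and the chloro in place of hydrogen gives a 5.5-fold higher number from compound 1 to compound 3 (0.74 log units; beyond the scatter) while the 3,4-difluorophenyl group had stayed within the scatter of phenyl. Among these three compounds, then, halogens on this ring do not all behave alike. Nothing measured here explains the gap. As far as these compounds go, a 4-fluorophenyl group would help separate the kind of halogen from its place on the ring, and what a methoxy group or an amine would do on this ring remains open.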